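A few compounds are considered here, and "the series" means these few. Any claim that something is new, unique, unknown or untested is made for them only; others in the source may bear on it.

Measured so far:
compound 1 `Cc1ccc2[nH]c(=O)c(CN(Cc3ccc(OCC(=O)O)cc3)Cc3ccc(C(C)(C)C)cc3)cc2c1` — > 10000 nM
compound 2 `Cc1ccc2[nH]c(=O)c(CN(Cc3ccc(C(C)(C)C)cc3)[C@H](C)c3ccc(F)cc3)cc2c1` — > 5000 nM

In a toxicity assay on MDCK cells (Canis lupus familiaris) for cytotoxicity, read by crystal violet staining, with a stated time of 48 h (on this read-out higher numbers stand for lower toxicity in this test and lower numbers for higher toxicity in this test), compound 1 reaches only a limit of the assay, > 10000 nM. Compound 2 also reaches only a limit, > 5000 nM. For the measured compounds named here, the one measured step, a step that the two limits leave unreadable from compound 1 to compound 2, therefore gives no readable size. Compound 3 `Cc1ccc2[nH]c(=O)c(CN(Cc3ccc(C(C)(C)C)cc3)C(C)c3ccc(OC(F)F)cc3)cc2c1` is built from compound 2 by 1-(4-(difluoromethoxy)phenyl)ethyl in place of 1-(4-fluorophenyl)ethyl on an amine nitrogen. Going by the values given here, with no step of readable size to lean on, no change beyond the usual scatter is expected in this assay. Compound 3 is estimated at 8000 nM, within 3000 nM to 20000 nM, which would be an expected step that the limit leaves unreadable from compound 2 to compound 3.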

Compound 3, half-maximal cytotoxic concentration: > 5000 nM
Compound 3 ended at the assay's limit; the forecaster's own chance of this, stated with the estimate: 75%; the middle value does not contradict the limit.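

For the compounds shown here, all three values of compound 1, compound 2 and compound 3 in this assay are limits, and no step between them can be read. From the compounds shown here alone, the concentration at which each compound becomes toxic to these cells stays open, as does any effect of the groups exchanged on the amine nitrogen.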